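The source may report more compounds than this note shows. Statements on the series, on what has been measured and on what is new or still open speak of the compounds shown alone.

Measured compounds:
compound 1, `CN(C)CCCCCSC1=Nc2ccccc2C(CC(=O)NCc2ccccc2)N1c1ccc(-c2ccccc2)cc1` — in a functional assay on A549 cells (Homo sapiens) for cytotoxicity, read by MTT assay, with a stated time of 48 h (a higher number here means a weaker inhibitor, a lower number a stronger inhibitor), compound 1 gives 18100 nM
compound 2, `O=C(CC1c2ccccc2N=C(SCCCCCN2CCCC2)N1c1ccc(-c2ccc(F)cc2)cc1)NCc1ccccc1` — in this assay compound 2 gives 17800 nM

Of the compounds shown here, two sharing one core have been measured so far. Compound 1 carries a plain biphenyl on the nitrogen of the shared core and a dimethylamino chain on the sulfur; compound 2 carries a fluorinated biphenyl and a pyrrolidinyl chain. In this assay the two compounds stand side by side: the value of compound 2 and that of compound 1 lie within the usual scatter of each other, so the numbers show no separation between them.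

Compound 3, `O=C(CC1c2ccccc2N=C(SCCCCCN2CCCC2)N1c1ccc(-c2ccccc2)cc1)NCc1ccccc1`, is not yet measured. It differs from compound 2 in one place: hydrogen in place of fluoro on an aromatic carbon. Going by the values given here, no single-point step between measured compounds exists to size this change. Since compound 1 and compound 2 already differ by this fluoro among other things and give values within the scatter, the expectation is a step of a 1.0-fold higher number from compound 2 to compound 3 (0.00 log units; within the scatter) of no size beyond the scatter, in no particular direction. Compound 3 is accordingly estimated at 18000 nM, within a range from 9000 nM to 36000 nM.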

Compound 3, half-maximal inhibitory concentration: 14900 nM
The estimate for compound 3 lay 1.2-fold (0.08 log units) above the measured number; measured number inside the range.
By their numbers in this assay, from the lowest: compounds 3, 2 and 1 (each within the scatter of the next).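

In this assay the change from 4-fluorophenyl to phenyl, para to a large group, now stands alone and reads a 1.2-fold lower number from compound 2 to compound 3 (0.08 log units; within the scatter) and so shows that the numbers do not tell fluoro and hydrogen apart at this position. The other difference carried by compounds 1 and 2 can also be read alone, since pyrrolidin-1-yl in place of dimethylamino on a saturated chain carbon, five bonds along the chain from a sulfur, reads a 1.2-fold lower number from compound 1 to compound 3 (0.08 log units; within the scatter) and likewise shows no separation, which neither single change could show while the two were combined. No supporting measurement bears on why either change leaves the values within the scatter.

Still open, from the compounds shown here alone, is whether another group at the same aromatic carbon, such as chloro, methoxy or a carboxylic acid, would give a step beyond the scatter. Also open, going by these compounds, is what a piperidine or morpholine in place of the pyrrolidine would do, and what a shorter or longer chain on the sulfur would do.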